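Changing the amide cap to a plain sulfonamide cap

The source may report more compounds than this note shows. Statements on the series, on what has been measured and on what is new or still open speak of the compounds shown alone.

Measured compounds:
compound 1, `O=S(=O)(NCCCNc1nccc(-c2c(-c3cccc(F)c3)nc3sccn23)n1)c1ccc(Br)cc1`, 7040 nM
compound 2, `O=C(NCCCNc1nccc(-c2c(-c3cccc(F)c3)nc3sccn23)n1)c1ccc(Cl)cc1`, 13700 nM

Both compounds share one core and differ only in the group on the amine nitrogen of the chain. In a functional assay on A-375 cells (Homo sapiens) for cytotoxicity, read by MTT assay (a higher number here means a weaker inhibitor, a lower number a stronger inhibitor), compound 1 gives 7040 nM and compound 2 gives 13700 nM; the step of a 1.9-fold higher number from compound 1 to compound 2 (0.29 log units; within the scatter) stays within the scatter, so compound 2 has the higher of the two numbers without the two being truly told apart.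

Compound 3, `O=S(=O)(NCCCNc1nccc(-c2c(-c3cccc(F)c3)nc3sccn23)n1)c1ccccc1`, has not been measured. Relative to compound 2 the change is phenylsulfonyl in place of (4-chlorophenyl)carbonyl on an amine nitrogen. Going by the values given here, this partly reverses the one step that is known, since a sulfonyl returns in place of the carbonyl, yet the halogen on the ring is also lost, and no measured pair speaks to that loss. Among the compounds with values here, the only step that bears on it, a 1.9-fold higher number from compound 1 to compound 2 (0.29 log units; within the scatter), was small, so no movement beyond the scatter is expected, and the estimated step of a 1.4-fold lower number from compound 2 to compound 3 (0.16 log units; within the scatter) is modest. For compound 3 a value of about 9500 nM is expected, with a range from 3500 nM to 26000 nM.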

Compound 3, half-maximal inhibitory concentration: 6600 nM
Estimate against measurement, compound 3: 1.4-fold (0.16 log units) above, and the stated range covers the measured number.
By their numbers in this assay, from the lowest: compounds 3, 1 and 2 (each within the scatter of the next, the first and the last beyond it).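

In this assay the group on the amine nitrogen now gives its first step beyond the scatter, a modest one: a 2.1-fold lower number from compound 2 to compound 3 (0.32 log units; beyond the scatter) when phenylsulfonyl takes the place of (4-chlorophenyl)carbonyl. The bromo group on the aromatic ring of compound 1 can be replaced by hydrogen with no difference that can be told apart, as a 1.1-fold lower number from compound 1 to compound 3 (0.03 log units; within the scatter) shows, so the halogen makes no visible difference between these two sulfonyl compounds. Nothing measured here explains these numbers.

The step to compound 3 swaps carbonyl for sulfonyl and removes chlorine at the same time, so it cannot show which of the two changes matters; a plain phenylcarbonyl group on the same nitrogen, or a (4-chlorophenyl)sulfonyl group, would separate them. On these data alone, it also remains open how the numbers would respond to a different kind of group on the ring, such as an amine or a carboxylic acid, or to a longer chain between the amine nitrogen and the shared core.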